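The source may hold more compounds than are shown below. What is called first, only, known or untested is meant among the compounds shown, and "the series" means these compounds.

Compound 1 `O=C(CN1CCN(c2ccccc2)CC1)N(c1ccccc1)c1ccccc1` gives 50 mg/kg in a toxicity assay on the whole organism (strain albino) for activation, with Mus musculus as the target, with stated times of 30 min and 240 min; a lower number here means that less compound is needed, a higher number that more compound is needed for the effect. Compound 2 `Cc1ccc(N2CCN(CC(=O)N(c3ccccc3)c3ccccc3)CC2)cc1` is known in this assay only as a limit, > 40 mg/kg. The step that the limit leaves unreadable from compound 1 to compound 2 cannot be sized because of the limit of > 40 mg/kg in this assay, at which 1 of the 2 values shown sits. Compound 3 `Cc1cccc(N2CCN(CC(=O)N(c3ccccc3)c3ccccc3)CC2)c1C` is not yet measured in this assay; it differs from compound 2 by 2,3-dimethylphenyl in place of 4-methylphenyl on an amine nitrogen in a ring. Among the compounds with values here, no measured step bears on this change, and the single measured step is itself unreadable. The step expected in this assay is therefore a step that the limit leaves unreadable from compound 2 to compound 3, within the scatter. For compound 3 the estimate in this assay is 50 mg/kg, with a range from 25 mg/kg to 100 mg/kg.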

Compound 3, dose for half-maximal effect: > 40 mg/kg
Compound 3: no number, only a limit (the forecaster's own chance of this, stated with the estimate: 50%); the middle value is on the limit's open side.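

In this assay, within the data shown here, no step from compound 1 or compound 2 to compound 3 can be read, because the comparison ends at a limit: the limit of > 40 mg/kg in this assay, at which 2 of the 3 values shown sit. On these data alone, whether 2,3-dimethylphenyl in place of 4-methylphenyl shifts the dose at all stays open.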